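Anilino halogen swap on the shared core: compound 4

A few compounds are considered here, and "the series" means these few. Any claim that something is new, unique, unknown or untested is made for them only; others in the source may bear on it.

Three members of the series share one core and differ only in the aryl group on the anilino nitrogen: compound 1 `C=CC(=O)Nc1cccc(NC(=O)CSc2nc(Nc3ccccc3F)c3ccccc3n2)c1`, compound 2 `C=CC(=O)Nc1cccc(NC(=O)CSc2nc(Nc3cccc(F)c3)c3ccccc3n2)c1` and compound 3 `C=CC(=O)Nc1cccc(NC(=O)CSc2nc(Nc3cccc(Br)c3)c3ccccc3n2)c1`. In a functional assay on PC-3 cells (Homo sapiens) for inhibition, read by MTT assay, with a stated time of 72 h (on this read-out lower numbers stand for stronger inhibition and higher numbers for weaker inhibition), compound 1 gives 9340 nM, compound 2 gives 5370 nM and compound 3 gives 15000 nM. Compound 3 thus holds the highest of the three numbers; the step of a 1.6-fold higher number from compound 1 to compound 3 (0.21 log units; within the scatter) stays within the scatter, whereas the step of a 2.8-fold higher number from compound 2 to compound 3 (0.45 log units; beyond the scatter) goes beyond it. The step of a 1.7-fold lower number from compound 1 to compound 2 (0.24 log units; within the scatter) shows that exchanging 2-fluorophenyl for 3-fluorophenyl changes little.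

Compound 4 `C=CC(=O)Nc1cccc(NC(=O)CSc2nc(Nc3ccc(Cl)cc3)c3ccccc3n2)c1` is the next member: 4-chlorophenyl in place of 3-bromophenyl on a nitrogen on an aromatic ring. Among the measured compounds shown here, no measured step covers a 4-chlorophenyl group, so the expectation rests on the two kinds of change already seen. Shifting a halogen to another ring position, as in a 1.7-fold lower number from compound 1 to compound 2 (0.24 log units; within the scatter) and a 1.6-fold higher number from compound 1 to compound 3 (0.21 log units; within the scatter), stayed within the scatter, while exchanging one halogen for another, as in a 2.8-fold higher number from compound 2 to compound 3 (0.45 log units; beyond the scatter), gave a modest step. The step is therefore expected to be a 1.6-fold lower number from compound 3 to compound 4 (0.20 log units; within the scatter), small and with the lower number somewhat more likely than the higher. Compound 4 is estimated at 9500 nM in this assay, with a range from 3500 nM to 26000 nM.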

Compound 4, half-maximal inhibitory concentration: 10800 nM
Compound 4: the middle estimate sits 1.1-fold (0.06 log units) below what was measured, within the range that was stated.
By their numbers in this assay, from the lowest: compounds 2, 1, 4 and 3 (each within the scatter of the next, the first and the last beyond it).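

A halogen on the 4-position of the ring, new in this series, fits among the earlier members in this assay: a 1.4-fold lower number from compound 3 to compound 4 (0.14 log units; within the scatter), a 2.0-fold higher number from compound 2 to compound 4 (0.30 log units; within the scatter) and a 1.2-fold higher number from compound 1 to compound 4 (0.06 log units; within the scatter), so compound 4 lies within the scatter of all three. Among the compounds shown here, the only pair beyond the scatter is still compound 2 and compound 3, so the series so far shows no clear separation at this position beyond that single pair, and 4-chlorophenyl does not add a second one. Because the step from 3-bromophenyl changes both the halogen and its ring position, these values cannot separate the two changes, and nothing at hand explains them.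

A 3-chlorophenyl or 4-bromophenyl group on the same nitrogen would separate the halogen from its position. As far as these compounds go, it also remains open whether an unsubstituted phenyl, a methoxy group, a carboxylic acid or an amine on this ring, or a longer chain in place of the ring, would take the number outside the narrow band seen with halogens.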